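The source may report more compounds than this note shows. Statements on the series, on what has been measured and on what is new or still open speak of the compounds shown alone.

Measured compounds:
- compound 1, `COc1ccc(-c2csc(N3N=C(c4ccc(F)cc4)CC3c3ccc4c(c3)OCCO4)n2)cc1` — 4530 nM
- compound 2, `Cc1ccc(C2=NN(c3nc(-c4ccc(Br)cc4)cs3)C(c3ccc4c(c3)OCCO4)C2)cc1` — 1590 nM
- compound 3, `COc1ccc(C2=NN(c3nc(-c4ccc(Br)cc4)cs3)C(c3ccc4c(c3)OCCO4)C2)cc1` — 2540 nM

All three were tested in a functional assay on MCF7 cells (Homo sapiens) for antiproliferative activity, read by MTT assay, with a stated time of 48 h; a higher number here means a weaker inhibitor, a lower number a stronger inhibitor. Compound 1 has the highest number of the three; its gap to compound 3 lies within the scatter, while its gap to compound 2 lies beyond it. Going by the values given here, the one change that can be read as a single step, from compound 2 to compound 3, gives a 1.6-fold higher number from compound 2 to compound 3 (0.20 log units; within the scatter), a shift within the scatter.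

Compound 4, `COc1ccc(-c2csc(N3N=C(c4ccc(Br)cc4)CC3c3ccc4c(c3)OCCO4)n2)cc1`, has not yet been measured. It differs from compound 1 in one place: bromo in place of fluoro on an aromatic carbon. Among the compounds with values here, no measured pair shows this exact change. Compounds 2 and 3 do carry a bromo group, but on a different ring of the shared core, so their values only show that bromo-bearing compounds here sit at lower numbers than compound 1, without an isolated step to rely on. The expectation for compound 4 in this assay is therefore a step of modest size, a 1.5-fold lower number from compound 1 to compound 4 (0.18 log units; within the scatter), most likely within or near the scatter. Compound 4 is estimated at 3000 nM, with a range from 1200 nM to 7500 nM.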

Compound 4, half-maximal inhibitory concentration: 870 nM
For compound 4 the middle estimate is 3.4-fold (0.54 log units) above the measured one, outside the stated range (below it).
By their numbers in this assay, from the lowest: compounds 4, 2, 3 and 1 (each within the scatter of the next, the first and the last beyond it).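

Replacing 4-fluorophenyl with 4-bromophenyl, para to a large group, gives a 5.2-fold lower number from compound 1 to compound 4 (0.72 log units; beyond the scatter) in this assay. Going by these compounds alone, the only earlier single step, methoxy in place of methyl, stayed within the scatter, so this is the first single change here that clearly moves the number. It shows that the choice of halogen at this position can matter on its own, although no available measurement explains the step.

Still open, as far as these compounds go, is what chloro or an amine at this same position would give, and so whether the numbers follow any order across such groups. This single pair also cannot show whether the same swap would give a step of similar size in compounds that differ elsewhere on the shared core.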